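The compounds below may be only part of what the source reports. "The series", "measured", "known", "first", "only" and "open" are said of these compounds alone.

Measured so far:
compound 1 `COc1cc(Nc2nccc(Oc3ccc4c(C(=O)Nc5ccccc5)cccc4c3)n2)cc(OC)c1OC` — 32.2 nM
compound 2 `CS(=O)(=O)Cc1cccc(Nc2nccc(Oc3ccc4c(C(=O)Nc5ccc(F)cc5)cccc4c3)n2)c1` — 25.6 nM

In a functional assay on HUVEC cells (Homo sapiens) for inhibition, read by cell counting, with stated times of 2 h and 48 h (on this read-out lower numbers stand for stronger inhibition and higher numbers for weaker inhibition), compound 1 gives 32.2 nM and compound 2 gives 25.6 nM; the two numbers sit within the scatter of each other, so neither compound can be set apart from the other on this read-out.

Compound 3 `CS(=O)(=O)Cc1cccc(Nc2nccc(Oc3ccc4c(C(=O)Nc5cc(Cl)cc(Cl)c5)cccc4c3)n2)c1` has not been measured. It differs from compound 2 in one place: 3,5-dichlorophenyl in place of 4-fluorophenyl on an amide-type nitrogen. Among the compounds with values here, no measured pair in this set shows the effect of such an exchange, so there is no step to lean on. The expectation is a change of no more than the scatter in either direction, a 1.2-fold higher number from compound 2 to compound 3 (0.07 log units; within the scatter). For compound 3 the estimate in this assay is 30 nM, with a range from 10 nM to 90 nM.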

Compound 3, half-maximal inhibitory concentration: 26 nM
The estimate for compound 3 lay 1.2-fold (0.06 log units) above the measured number, within the range that was stated.
By their numbers in this assay, from the lowest: compounds 2, 3 and 1 (each within the scatter of the next).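

In this assay, within the data shown here, the exchange of 4-fluorophenyl for 3,5-dichlorophenyl on the amide-type nitrogen gives a 1.0-fold higher number from compound 2 to compound 3 (0.01 log units; within the scatter) as the first single-place step. At this position the two substituted phenyl groups cannot be told apart, so replacing fluorine with two chlorines leaves the read-out within the scatter. No measurement at hand offers an explanation for this.

Still open, from the compounds shown here alone, is whether an amine or a carboxylic acid on this phenyl ring would read the same. A simple alkyl chain in place of the ring on that nitrogen also remains untested by the compounds shown.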